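One stereocentre inverted: compound 2 to compound 3

The source may report more compounds than this note shows. Statements on the series, on what has been measured and on what is new or still open speak of the compounds shown alone.

In a functional assay on HOS cells (Homo sapiens) for antiproliferative activity, read by sulforhodamine B assay (a lower number here means a stronger inhibitor of growth, a higher number a weaker inhibitor of growth), compound 1 `CC[C@H]1O[C@H](COCc2ccccc2)[C@@H](OCc2ccccc2)[C@H](OCc2ccccc2)[C@H]1O` gives > 50000 nM, and this is a limit of the assay, not a number.

For the measured compounds named here, compound 2 `CCC[C@@H]1O[C@H](COCc2ccccc2)[C@@H](OCc2ccccc2)[C@H](OCc2ccccc2)[C@H]1O` gives 38600 nM in this assay, the only true number so far. Going by the values given here, with so little data, its standing can be stated only this way, and no measured step is available for calibration.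

Compound 3 `CCC[C@H]1O[C@H](COCc2ccccc2)[C@@H](OCc2ccccc2)[C@H](OCc2ccccc2)[C@H]1O` has the same atoms and bonds as compound 2 and changes only in drawn configuration: the two compounds have the same atoms and bonds and differ only in configuration as drawn: 1 of 5 stereo elements differ; a stereocentre at a saturated ring carbon is drawn S in compound 2 and R in compound 3. Among the compounds with values here, no pair of measured compounds shows what such an inversion does in this assay. The expectation therefore rests on compound 2 at 38600 nM, with no direction favoured and no change expected beyond the usual scatter. The expected step is a 1.0-fold higher number from compound 2 to compound 3 (0.02 log units; within the scatter). A reading reported only as a limit remains a real possibility. For compound 3 the estimated value is 40000 nM, with an expected range of 18000 nM to 50000 nM.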

Compound 3, concentration for 50% growth inhibition: 23600 nM
Compound 3: the middle estimate sits 1.7-fold (0.23 log units) above what was measured; the range from low to high includes it.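

In this assay, the inversion at the saturated ring carbon gives the series its first measured step of this kind, a 1.6-fold lower number from compound 2 to compound 3 (0.21 log units; within the scatter), so the drawn configuration at this position, S in one compound and R in the other, does not separate the two numbers beyond the usual scatter, and this comparison isolates that single centre: the fact that compounds 2 and 3 differ only in the configuration as drawn.
For compound 1 the reading > 50000 nM is a limit of the assay and not a number.
Methyl in place of hydrogen on a saturated chain carbon, two bonds along the chain from a saturated ring carbon, is read as an at least 2.1-fold lower number from compound 1 to compound 3 (0.32 log units; beyond the scatter) and is the first step in the series beyond the scatter, although its size is fixed from one side only: the limit of > 50000 nM in this assay, at which 1 of the 3 values shown sits.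

Going by these compounds, whether a longer chain such as butyl at this ring carbon, or an amine or a carboxylic acid at the end of the chain, would shift the number further remains open. The remaining groups on the shared core are the same in all three compounds, so their contribution to these readings cannot be told from the compounds shown.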